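Propylphenyl to methoxyphenyl on the aminoquinone core

The source may report more compounds than this note shows. Statements on the series, on what has been measured and on what is new or still open speak of the compounds shown alone.

Of the compounds shown here, three sharing one core have been measured in a functional assay on HeLa cells (Homo sapiens) for inhibition, read by sulforhodamine B assay; on this read-out lower numbers stand for stronger inhibition and higher numbers for weaker inhibition. Compound 1 `CCCc1ccc(NC2=CC(=O)c3nc4n(c3C2=O)[C@H]2OC[C@@H](O)[C@H]2OC4)cc1` carries a 4-propylphenyl group on its amine nitrogen, and in this assay compound 1 gives 4990 nM, the lowest of the two numbers reported. Compound 3 `CCCc1ccc(NC2=CC(=O)c3c(nc4n3[C@H]3OC[C@@H](O)[C@H]3OC4)C2=O)cc1` is a regioisomer of compound 1; in this assay compound 3 gives 6030 nM, and the two numbers lie within the scatter of each other, so no order can be read between them. Compound 2 `O=C1C(N2CCC2)=CC(=O)c2c1nc1n2[C@H]2OC[C@@H](O)[C@H]2OC1`, with an azetidine in place of the arylamine, reaches only a limit of the assay, > 16000 nM in this assay; the evidence states it as the limit of > 16000 nM in this assay, at which 1 of the 3 values shown sits.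

Compound 4 `COc1cccc(NC2=CC(=O)c3nc4n(c3C2=O)[C@H]2OC[C@@H](O)[C@H]2OC4)c1` has not yet been measured. It differs from compound 1 in one place: 3-methoxyphenyl in place of 4-propylphenyl on an amine nitrogen. Among the measured compounds shown here, no step between measured compounds tells what such a swap on the arylamine does. The aryl ring is kept, with one small substituent exchanged for another, so the expected step from compound 1 to compound 4, a 1.4-fold higher number from compound 1 to compound 4 (0.15 log units; within the scatter), is small and toward a slightly higher number. Compound 4 is therefore estimated at 7000 nM in this assay, with a likely range from 2500 nM to 20000 nM.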

Compound 4, half-maximal inhibitory concentration: 4280 nM
Estimate against measurement, compound 4: 1.6-fold (0.21 log units) above; the measured number falls inside the stated range.
By their numbers in this assay, from the lowest: compounds 4, 1 and 3 (each within the scatter of the next). At a limit, above all of these: compound 2.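

Among the compounds shown here, the first step that can be read on the arylamine in this assay is a 1.2-fold lower number from compound 1 to compound 4 (0.07 log units; within the scatter), so compound 4 and compound 1 cannot be told apart in this assay. This holds although the exchange on the amine nitrogen alters more than one feature of the aryl group: 4-propylphenyl carries a propyl chain and no hydrogen-bond acceptor, whereas 3-methoxyphenyl carries a methoxy group and one hydrogen-bond acceptor, and the two substituents are numbered differently on the ring. The two compounds therefore show that this site on the shared core tolerates both of these aryl groups without a difference that can be read, but nothing measured here gives a reason for this.

Going by these compounds, it remains open whether the same holds for an unsubstituted phenyl ring, or for a phenyl ring bearing a carboxylic acid, an amine or a longer alkyl chain. On these data alone, it is also open whether 3-methoxyphenyl would behave in the same way on the regioisomeric core of compound 3, and whether either aryl group contributes to the read-out at all.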